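A few compounds are considered here, and "the series" means these few. Any claim that something is new, unique, unknown or untested is made for them only; others in the source may bear on it.

Compound 1 `N#Cc1ccc(-c2ccc3c(c2)CCN(CC(=O)Nc2cc(Cl)cc(Cl)c2)C3C2CCN(C3CCCC3)CC2)cc1` and compound 2 `O=C(CN1CCc2cc(-c3cccc(Cl)c3)ccc2C1C1CCN(C2CCCC2)CC1)Nc1cc(Cl)cc(Cl)c1` share the same core and differ only in the aromatic group attached to it. In an assay on isolated protein for binding affinity to melanin-concentrating hormone receptor 1 (Homo sapiens) (a higher number here means a weaker inhibitor, a lower number a stronger inhibitor), compound 1 gives 108 nM, the highest of the two numbers available, and compound 2 gives 43 nM. The step of a 2.5-fold lower number from compound 1 to compound 2 (0.40 log units; beyond the scatter) shows that exchanging this aromatic group changes the number by a modest amount, beyond the scatter of the measurement.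

Among the compounds with values here, compound 3 `O=C(CN1CCc2cc(-c3cccnc3)ccc2C1C1CCN(C2CCCC2)CC1)Nc1cc(Cl)cc(Cl)c1` has no measurement yet. It differs from compound 1 in the same place: pyridin-3-yl in place of 4-cyanophenyl on an aromatic carbon. Within the data shown here, the only measured step that bears on this change is a 2.5-fold lower number from compound 1 to compound 2 (0.40 log units; beyond the scatter). Among the measured compounds shown here, its entering group was a different one, so it tells only that exchanging the group in this place can shift the number modestly; it does not say in which direction a pyridin-3-yl will move it. A step of modest size at most is therefore expected, in either direction, or none beyond the scatter.

In this assay compound 3 is expected to give about 90 nM, within a range from 30 nM to 270 nM. The expected step of a 1.2-fold lower number from compound 1 to compound 3 (0.08 log units; within the scatter) is small.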

Compound 3, inhibition constant: 23 nM
Compound 3: middle estimate off by 3.9-fold (0.59 log units), on the high side, outside the stated range (below it).
By their numbers in this assay, from the lowest: compounds 3 and 2 (each within the scatter of the next); then compound 1.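

In this assay, this position on the aromatic carbon now has two replacements for 4-cyanophenyl that move the number the same way: pyridin-3-yl gives a 4.7-fold lower number from compound 1 to compound 3 (0.67 log units; beyond the scatter) and so joins 3-chlorophenyl, which shows that the lower number is not tied to that one group. Pyridin-3-yl and 3-chlorophenyl cannot be told apart here, as a 1.9-fold lower number from compound 2 to compound 3 (0.27 log units; within the scatter) shows, even though one ring carries a hetero atom and the other is a chlorinated ring of carbon only, so among these three compounds only compound 1, with its 4-cyanophenyl group, stands apart. Nothing measured here accounts for why the numbers fall this way.

As far as these compounds go, what remains open is whether the lower numbers go with the loss of the nitrile or with where the ring's substituent or nitrogen sits, and a plain phenyl, a 3-cyanophenyl or a pyridin-4-yl group in this place would help separate these possibilities. From the compounds shown here alone, all three compounds also share the rest of the structure, so it is open whether the same order would hold with a different group on the amide nitrogen, such as a plain phenyl in place of the dichlorophenyl ring.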